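Anilide series: dropping the chloro from compound 2

The compounds below may be only part of what the source reports. "The series", "measured", "known", "first", "only" and "open" are said of these compounds alone.

compound 1 `COc1cccc(CCC(=O)Nc2nc3ccccc3c(=O)s2)c1` — 621 nM
compound 2 `O=C(CCCc1ccccc1)Nc1nc2ccc(Cl)cc2c(=O)s1` — > 10000 nM

In an assay on mitochondria (strain Sprague-Dawley) for inhibition of Amine oxidase [flavin-containing] B (Rattus norvegicus), read by fluorescence and Amplex Red, with stated times of 30 min and 45 min (on this read-out higher numbers stand for weaker inhibition and lower numbers for stronger inhibition), compound 1 gives 621 nM. For compound 2 this assay reports only a limit, > 10000 nM, so compound 2 sits at the limit of > 10000 nM in this assay, at which 1 of the 2 values shown sits. Compound 3 `O=C(CCCc1ccccc1)Nc1nc2ccccc2c(=O)s1` differs from compound 2 by hydrogen in place of chloro on an aromatic carbon. For the measured compounds named here, no measured pair covers this change, so its size is not known from the data. The expected step is an at least 3.3-fold lower number from compound 2 to compound 3 (0.52 log units; beyond the scatter) toward stronger inhibition, because compound 1 with the same unsubstituted core gives 621 nM. Compound 3 is estimated at 3000 nM, with a range of 500 nM to 20000 nM.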

Compound 3, half-maximal inhibitory concentration: 186 nM
Compound 3: the middle estimate sits 16-fold (1.21 log units) above what was measured; the measured number lies below the stated range.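

Hydrogen in place of chloro on this aromatic carbon gives an at least 53-fold lower number from compound 2 to compound 3 (1.73 log units; beyond the scatter). As far as these compounds go, the true size of that step stays unknown, as the value for compound 2 is only a limit: the limit of > 10000 nM in this assay, at which 1 of the 3 values shown sits. With this position unsubstituted, the chain change is far smaller, benzyl in place of 3-methoxyphenyl giving a 3.3-fold lower number from compound 1 to compound 3 (0.52 log units; beyond the scatter).

Open, from the compounds shown here alone, is how fluoro, methoxy or an amine on this carbon would compare with hydrogen and chloro. Also open, going by these compounds, is whether chloro has a similar effect when paired with the 3-methoxyphenyl chain of compound 1.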